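A few compounds are considered here, and "the series" means these few. Any claim that something is new, unique, unknown or untested is made for them only; others in the source may bear on it.

For the measured compounds named here, compound 1 `COC(=O)[C@@H]1C[C@@]2(CC=C(C)C)c3ccccc3N3C(=N)[C@H](Cc4ccccc4)N1[C@H]32` is the only member of this small set with a measured number: in a functional assay on A549 cells (Homo sapiens) for cytotoxicity, read by sulforhodamine B assay, with a stated time of 48 h (a lower number here means a stronger inhibitor of growth, a higher number a weaker inhibitor of growth), compound 1 gives 24100 nM. Its two companions differ from it at a single saturated ring carbon. Compound 2 `COC(=O)[C@@H]1C[C@@]2(CC=C(C)C)c3ccccc3N3C(=N)[C@H](c4ccccc4)N1[C@H]32` carries a phenyl in place of the benzyl, and in this assay compound 2 reaches only a limit, > 100000 nM. Compound 3 `COC(=O)[C@@H]1C[C@@]2(CC=C(C)C)c3ccccc3N3C(=N)[C@H](C(C)(C)C)N1[C@H]32` carries a tert-butyl at that carbon, and compound 3 likewise stops at a limit, > 100000 nM. The steps of an at least 4.1-fold higher number from compound 1 to compound 2 (0.61 log units; beyond the scatter) and an at least 4.1-fold higher number from compound 1 to compound 3 (0.61 log units; beyond the scatter) show that replacing the benzyl costs growth inhibition, while a step that the two limits leave unreadable from compound 2 to compound 3 cannot be sized, since both values sit at the limit of > 100000 nM in this assay, at which 2 of the 3 values shown sit.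

Compound 4 `COC(=O)[C@@H]1C[C@]2(CC=C(C)C)c3ccccc3N3C(=N)[C@@H](Cc4ccccc4)N1[C@@H]32` keeps the benzyl and every atom and bond of compound 1; the change is purely spatial: the two compounds have the same atoms and bonds; at least one stereo element is drawn with a configuration in one of them and without one in the other: 3 of 5 stereo elements differ; a stereocentre at a saturated ring carbon is drawn S in compound 1 and R in compound 4; a stereocentre at a saturated ring carbon is drawn S in compound 1 and R in compound 4; a stereocentre at a saturated ring carbon is drawn R in compound 1 and S in compound 4. Going by the values given here, none of the measured steps involves a change of configuration, so none bears directly on this move; they report only what happens when the benzyl itself is exchanged. With no stereochemical comparison available, the expected step of a 1.2-fold higher number from compound 1 to compound 4 (0.10 log units; within the scatter) is uncertain in both direction and size, and the estimate for compound 4 is 30000 nM, within a range from 8000 nM to 100000 nM.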

Compound 4, concentration for total growth inhibition: 24100 nM
Compound 4: middle estimate off by 1.2-fold (0.10 log units), on the high side; the range from low to high includes it.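

In this assay, the spatial change leaves the reading untouched, with no change at the digits printed from compound 1 to compound 4 (within the scatter), whereas exchanging the benzyl for phenyl or tert-butyl had raised the number beyond the scatter. This is the first sign in the set that the drawn configuration at these three saturated ring carbons can change together with no readable effect on growth inhibition, so among the compounds shown, only the group exchange separates one result from another. This reading needs some caution, since a comparison of configurations is only as firm as the drawings behind it: the fact that one of compounds 1 and 4 is drawn with a defined configuration and the other without, at the place where they differ

Changing the three carbons together also leaves open what each does alone, since opposite effects at separate carbons could cancel, and a form with just one of them changed would test that. Going by these compounds, it also remains open whether a longer chain such as phenethyl, or a benzyl bearing a hydroxyl or an amine on its ring, would bring the number down, or whether either spatial form would respond differently to such a group.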